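The source may report more compounds than this note shows. Statements on the series, on what has been measured and on what is new or still open speak of the compounds shown alone.

Measured so far:
compound 1, `CCCCCCCCC[C@]1(CO)NC[C@@H](O)[C@@H]1O`: 130000 nM
compound 2, `OC[C@@]1(c2ccc(O)cc2)NC[C@@H](O)[C@@H]1O`: 372000 nM
compound 3, `CCCCCCCCC[C@@]1(CO)NC[C@H](O)[C@H]1O`: 3700 nM

In an assay on isolated protein for inhibition of lysosomal alpha-glucosidase (Homo sapiens) (a higher number here means a weaker inhibitor, a lower number a stronger inhibitor), compound 1 stands second highest of the three numbers, with compound 2 giving a higher number and compound 3 a far lower one. Among the compounds with values here, the only single-point step among them, a 35-fold lower number from compound 1 to compound 3 (1.55 log units; beyond the scatter), rests on the fact that compounds 1 and 3 differ only in the configuration as drawn and concerns configuration alone. Compound 4, `CCCC[C@]1(CO)NC[C@@H](O)[C@@H]1O`, differs from compound 1 in the chain instead: hydrogen in place of pentyl on a saturated chain carbon, four bonds along the chain from a saturated ring carbon. Within the data shown here, no measured step bears on shortening the chain, so the direction of the step in this assay is uncertain, and a modest weakening is the guess. Compound 4 is expected to give 300000 nM, within 80000 nM to 1200000 nM, a step of a 2.3-fold higher number from compound 1 to compound 4 (0.36 log units; beyond the scatter).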

Compound 4, half-maximal inhibitory concentration: 79000 nM
Beside the measured number, compound 4's estimate is 3.8-fold (0.58 log units) above it; measured number below the stated range.
By their numbers in this assay, from the lowest: compound 3; then compounds 4 and 1 (each within the scatter of the next); then compound 2.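

In this assay, putting hydrogen in place of pentyl on this saturated chain carbon gives a 1.6-fold lower number from compound 1 to compound 4 (0.22 log units; within the scatter) and so the two chain lengths cannot be told apart here. At this position and in this configuration, the shorter chain of compound 4 therefore keeps the level of compound 1 rather than changing it. Nothing known about the compounds bears on why this is so.

From the compounds shown here alone, whether the same shortening would matter in the mirror-image configuration of compound 3 remains open. So does the effect of a longer chain, or of a chain carrying a carboxylic acid or an amine.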